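The compounds below may be only part of what the source reports. "The series", "measured", "known", "first", "only" and "open" are said of these compounds alone.

Working notes on the series. Compound 2 `OCCCNc1nc(-c2ccccc2)nc2c1nnn2Cc1ccccc1` carries the shared core with a (3-hydroxypropyl)amino chain; in an assay on isolated protein for binding affinity to adenosine receptor A1 (Bos taurus) (on this read-out higher numbers stand for weaker inhibition and lower numbers for stronger inhibition), compound 2 gives 21400000 nM. Compound 1 `OCCCNc1nc(-c2ccccc2)nc2c1nnn2Cc1ccccc1Cl` adds a chloro on an aromatic carbon, and in this assay compound 1 gives 33000000 nM. Compound 3 `CCCCCCNc1nc(-c2ccccc2)nc2c1nnn2Cc1ccccc1F` differs from compound 2 in two places, a hexylamino chain and a fluoro; in this assay compound 3 gives 25000000 nM. Of the three numbers, that of compound 2 is the smallest, yet compound 3 and compound 1 both lie within the scatter of it, so nothing separates the three. Going by the values given here, the one single-point step measured, a 1.5-fold lower number from compound 1 to compound 2 (0.19 log units; within the scatter), shows a change on an aromatic carbon leaving the number essentially unchanged.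

Compound 4 `CCNc1nc(-c2ccccc2)nc2c1nnn2Cc1ccccc1` is the unmeasured member; it arises from compound 2 by hydrogen in place of hydroxymethyl on a saturated chain carbon, two bonds along the chain from a nitrogen on an aromatic ring. Among the compounds with values here, no measured step alters the amino chain alone. Compound 3 set against compound 2 combines a longer chain with a second change, and their two numbers sit within the scatter of each other, which gives no sign of a chain effect in this assay. Compound 4 is therefore expected to show a step of a 1.0-fold higher number from compound 2 to compound 4 (0.01 log units; within the scatter) that stays inside the scatter. The estimate for compound 4 is 22000000 nM, with a range from 7000000 nM to 65000000 nM.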

Compound 4, inhibition constant: 91000000 nM
Beside the measured number, compound 4's estimate is 4.1-fold (0.62 log units) below it, and the stated range ends below it.
By their numbers in this assay, from the lowest: compounds 2, 3 and 1 (each within the scatter of the next); then compound 4.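

Going by these compounds alone, the step from the (3-hydroxypropyl)amino chain to the ethylamino chain is the only measured change on the amino chain alone, and in this assay it reads a 4.3-fold higher number from compound 2 to compound 4 (0.63 log units; beyond the scatter). This shows that a change on a saturated chain carbon, two bonds along the chain from a nitrogen on an aromatic ring, can move the number beyond the scatter, here towards weaker inhibition, whereas the change on an aromatic carbon, a 1.5-fold lower number from compound 1 to compound 2 (0.19 log units; within the scatter), stayed within it. No measurement shown gives an explanation for this step.

Losing hydroxymethyl removes the hydroxyl and shortens the chain together, so the compounds shown do not tell which of the two goes with the step; a propylamino chain without the hydroxyl and a (2-hydroxyethyl)amino chain would separate them. Also open, on these data alone, is how the number responds to an amine or a carboxylic acid at the end of the chain, or to a longer chain ending in a hydroxyl, with the rest of compound 2 unchanged.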